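Tert-Butyl for Trifluoromethyl: Estimating Compound 4

The source may hold more compounds than are shown below. What is called first, only, known or untested is meant among the compounds shown, and "the series" means these compounds.

Measured compounds:
compound 1 `CC1CCN(c2nc(C(F)(F)F)ccc2CNC(=O)Nc2cccc3c(=O)[nH]ccc23)CC1` — 9.59 nM
compound 2 `CCCN(CCC)c1nc(C(F)(F)F)ccc1CNC(=O)Nc1cccc2c(=O)[nH]ccc12` — 2.79 nM
compound 3 `O=C(NCc1cc(C(F)(F)F)nn1-c1cccc(Cl)c1)Nc1cccc2c(=O)[nH]ccc12` — 41.4 nM

In an assay on CHO cells for agonist activity at transient receptor potential cation channel subfamily V member 1 (Homo sapiens) (a higher number here means that more compound is needed for the effect, a lower number that less compound is needed), compound 3 gives the highest number of the three; compound 1 lies lower, and compound 2 lower still. Within the data shown here, the only measured single-point step, a 3.4-fold lower number from compound 1 to compound 2 (0.54 log units; beyond the scatter), concerns a different part of the molecule and does not touch the change considered here. Compound 4 `CC(C)(C)c1cc(CNC(=O)Nc2cccc3c(=O)[nH]ccc23)n(-c2cccc(Cl)c2)n1` differs from compound 3 by tert-butyl in place of trifluoromethyl on an aromatic carbon. Among the measured compounds shown here, no measured pair exchanges these two groups, so nothing anchors a direction, and the expected step is a 1.3-fold lower number from compound 3 to compound 4 (0.11 log units; within the scatter), judged to lie within the scatter. Compound 4 is therefore estimated at 32 nM, with a range from 8 nM to 130 nM.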

Compound 4, half-maximal effective concentration: 9.59 nM
Compound 4: middle estimate off by 3.3-fold (0.52 log units), on the high side, and the stated range covers the measured number.
By their numbers in this assay, from the lowest: compound 2; then compounds 1 and 4 (each within the scatter of the next); then compound 3.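

At the ring carbon two ring bonds from the atom bearing the 3-chlorophenyl group, tert-butyl in place of trifluoromethyl gives a step in this assay (a 4.3-fold lower number from compound 3 to compound 4 (0.64 log units; beyond the scatter)). The earlier compounds shown here held no pair at this position, and this one shows that exchanging these two groups, each of 4 heavy atoms, moves the number beyond the scatter. Nothing measured here accounts for the step. As far as these compounds go, whether methyl, isopropyl or a carboxylic acid at this carbon would lower the number further stays open, as does whether the same exchange gives a like step on the core of compound 1.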